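Methoxy in Place of Chloro Across Two Related Pairs

This account rests on a few compounds, and the source may have more. Where it says the series, first, only, none or still open, it means among the compounds named here.

Compound 1 `O=C(CBr)Nc1ccc(C(=O)/C=C/c2ccc(Cl)cc2)cc1` and compound 2 `COc1ccc(/C=C/C(=O)c2ccc(NC(=O)CBr)cc2)cc1` differ in one place only, (methoxy in place of chloro on an aromatic carbon). In a functional assay on the whole organism (strain albino) for inhibition, with Rattus norvegicus as the target, read by paw edema, with stated times of 30 min and 4 h, at a dose of 100 mg/kg by the oral route (on this read-out higher numbers stand for more inhibition at the one dose given (going by the name of the read-out) and lower numbers for less inhibition), compound 1 gives 59%, and in this assay compound 2 gives 41%. The step of a number 18 percentage points lower from compound 1 to compound 2 (beyond the scatter) lies beyond the usual scatter. Compound 3 `O=C(COCc1c(-c2ccccc2)no[n+]1[O-])Nc1ccc(C(=O)/C=C/c2ccc(Cl)cc2)cc1` carries a much larger group on the amide side than compound 1; the difference between the two cores is not broken down here. In this assay compound 3 gives 75%, the highest of the three numbers, with its gaps to compound 1 and compound 2 both beyond the scatter. Compound 4 `COc1ccc(/C=C/C(=O)c2ccc(NC(=O)COCc3c(-c4ccccc4)no[n+]3[O-])cc2)cc1`, not yet measured, relates to compound 3 through (methoxy in place of chloro on an aromatic carbon), the same change, made at the same kind of place, as that from compound 1 to compound 2. Because a number 18 percentage points lower from compound 1 to compound 2 (beyond the scatter) was a modest but clear loss, a loss of similar size is expected here, namely a number 18 percentage points lower from compound 3 to compound 4 (beyond the scatter). For compound 4 the estimated inhibition in this assay is 57%, expected to fall between 43% and 70%.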

Compound 4, a percentage reported as inhibition, in the whole organism at one dose (the size of the read-out at that dose, not a potency): 55%
For compound 4 the middle estimate is 2 percentage points above the measured one; the range from low to high includes it.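

In this assay, methoxy in place of chloro on the second core gives a number 20 percentage points lower from compound 3 to compound 4 (beyond the scatter), and this step matches the one seen on the first core: the same change on two cores in this assay, a number 18 percentage points lower (beyond the scatter) from compound 1 to compound 2 and a number 20 percentage points lower (beyond the scatter) from compound 3 to compound 4, 2 percentage points apart, within the scatter of two such steps. In this series, then, the change from 4-chlorophenyl to 4-methoxyphenyl costs about the same amount of inhibition whether the amide side carries the small bromine-bearing group of compound 1 or the much larger group of compound 3. For the compounds shown here, this rests on only two pairs of compounds, tested in a single assay at a single dose, so it does not show why the loss occurs, whether it would carry over to any other core, or whether it would hold at other doses.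

The compounds shown leave open what other groups at this place on the ring would give, such as a fluoro, a hydroxyl or an amine. They also leave open whether the same step would appear with a carboxylic acid or a longer chain on the amide side.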